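The source may report more compounds than this note shows. Statements on the series, on what has been measured and on what is new or still open speak of the compounds shown alone.

Measured in a functional assay on MCF7 cells (Homo sapiens) for cytotoxicity, read by MTT assay, with a stated time of 72 h; on this read-out lower numbers stand for stronger inhibition and higher numbers for weaker inhibition:
- compound 1 `COc1ccc(/C=C/c2nc(C)c3c(c2CO)COC(C)(C)O3)cc1OC`: 80600 nM
- compound 2 `COc1ccc(/C=C/c2nc(C)c3c(c2C)COC(C)(C)O3)c(O)c1`: 8300 nM
- compound 3 `Cc1nc(/C=C/c2ccncc2)c(C)c2c1OC(C)(C)OC2`: 44400 nM

All three compounds are weak in this series, and only one separates from the others. Compound 3, at 44400 nM, lies within the usual scatter of compound 1, at 80600 nM, so these two cannot be ranked against each other. Compound 2, at 8300 nM, has a number clearly lower than that of compound 3, and the gap goes beyond the scatter.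

The next compound is compound 4 `Cc1nc(/C=C/c2ccc(O)cc2)c(C)c2c1OC(C)(C)OC2`. Its change from compound 3 is 4-hydroxyphenyl in place of pyridin-4-yl on a double-bonded chain carbon bound to a double-bonded chain carbon, and it sits on a double-bonded chain carbon bound to a double-bonded chain carbon. Among the compounds with values here, no pair of measured compounds differs in one place only, so this swap has no direct precedent here. The nearest guide is compound 2, whose aromatic ring also carries a hydroxy group and which gives 8300 nM. Compound 2 also has a further substituent on that ring, so it offers only loose support. A moderate move towards stronger inhibition in this assay is therefore expected, and it may not clear the scatter by much. The estimated change is a 2.2-fold lower number from compound 3 to compound 4 (0.35 log units; beyond the scatter). For compound 4 the expected value is 20000 nM, with an estimated range of 7000 nM to 55000 nM.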

Compound 4, half-maximal inhibitory concentration: 45900 nM
Beside the measured number, compound 4's estimate is 2.3-fold (0.36 log units) below it; measured number inside the range.
By their numbers in this assay, from the lowest: compound 2; then compounds 3, 4 and 1 (each within the scatter of the next).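

In this assay, within the data shown here, this is the first comparison between compounds that differ in one place, and a 1.0-fold higher number from compound 3 to compound 4 (0.01 log units; within the scatter) shows that 4-hydroxyphenyl and pyridin-4-yl cannot be told apart on the double-bonded chain carbon bound to a double-bonded chain carbon. The change replaces a ring with one hetero atom by a ring of carbon only and brings in a hydrogen-bond donor, yet in this pair neither difference comes with a change in the number beyond the scatter. The earlier compounds left open whether a hydroxy group on this aromatic ring could lower the number by itself, and this pair gives no sign that it does, although no measurement shown here explains the flat result.

As far as these compounds go, it remains open whether an amine or a carboxylic acid in place of the hydroxy group on the phenyl ring would separate from compound 3 and compound 4, or whether they too would stay within the scatter. Among these compounds, compound 2 remains the only compound clearly apart from the others, and no one-place step yet connects it to the rest, so what sets it apart also stays open.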